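Chalcone-type growth inhibitors: an aminodibromophenyl replacement

This account rests on a few compounds, and the source may have more. Where it says the series, first, only, none or still open, it means among the compounds named here.

Measured compounds:
compound 1 `O=C(/C(=C\c1ccc(Cl)cc1)S(=O)(=O)c1ccc(Br)cc1)c1ccc(Br)cc1`: 50000 nM
compound 2 `O=C(/C(=C\c1ccc(OC(F)(F)F)cc1)S(=O)(=O)c1ccc(Br)cc1)c1ccc(Br)cc1`: 25000 nM
compound 3 `CCOc1cc(/C=C(\Cc2ccc(Cl)cc2Cl)C(=O)c2ccc(Cl)cc2)ccc1O`: 10000 nM

Working notes. In a functional assay on DU-145 cells (Homo sapiens) for inhibition, read by trypan blue exclusion, with a stated time of 96 h (a higher number here means a weaker inhibitor of growth, a lower number a stronger inhibitor of growth), compound 1 gives 50000 nM, the highest of the three numbers. Its nearest neighbour is compound 2 at 25000 nM, reached by a 2.0-fold lower number from compound 1 to compound 2 (0.30 log units; within the scatter). Furthest from compound 1 stands, on a different core, compound 3 at 10000 nM, a gap beyond the scatter.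

Compound 4 `Nc1c(Br)cc(Br)cc1/C=C(\C(=O)c1ccc(Br)cc1)S(=O)(=O)c1ccc(Br)cc1` is not yet measured. Relative to compound 1 the change is 2-amino-3,5-dibromophenyl in place of 4-chlorophenyl on a double-bonded chain carbon bound to a double-bonded chain carbon. For the measured compounds named here, the only measured step that bears on it is the substituent change on the same aryl group, a 2.0-fold lower number from compound 1 to compound 2 (0.30 log units; within the scatter), which stayed within the scatter. The present change is larger in what it counts, but nothing measured shows how such an entering group behaves in this series, so the expected step from compound 1 to compound 4 is a 1.7-fold lower number from compound 1 to compound 4 (0.22 log units; within the scatter), a modest expected lowering with wide uncertainty. Compound 4 is therefore estimated at 30000 nM, within 8000 nM to 100000 nM.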

Compound 4, concentration for 50% growth inhibition: 25000 nM
Compound 4: middle estimate off by 1.2-fold (0.08 log units), on the high side; the range from low to high includes it.
By their numbers in this assay, from the lowest: compound 3; then compounds 2, 4 and 1 (each within the scatter of the next).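

In this assay, 2-amino-3,5-dibromophenyl in place of 4-chlorophenyl, on a double-bonded chain carbon bound to a double-bonded chain carbon, gives a 2.0-fold lower number from compound 1 to compound 4 (0.30 log units; within the scatter). The earlier step at this place exchanged only one substituent on the aryl group, whereas this one brings in an amino group and two bromines together, so the place accepts a more heavily substituted aryl group with the number still inside the scatter. Nothing measured on these compounds gives a reason for this result.

From the compounds shown here alone, the 2-amino-3,5-dibromophenyl group enters as a single unit, so the separate contributions of the amino group and the two bromines remain open. Also open, going by these compounds, is how a carboxylic acid, a morpholine or a longer alkyl chain on the aryl group at this place would read.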